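From benzyloxy to ethyl on a carbonyl carbon

The source may hold more compounds than are shown below. What is called first, only, known or untested is meant among the compounds shown, and "the series" means these compounds.

For the measured compounds named here, in a functional assay on HCT-116 cells (Homo sapiens) for inhibition, read by MTT assay, with a stated time of 96 h (a lower number here means a stronger inhibitor of growth, a higher number a weaker inhibitor of growth), compound 1 (`O=C(OCc1ccccc1)SCCCCCCNC(=O)c1cc(-c2ccncc2)n[nH]1`) gives 18200 nM and is the only compound so far with a measured number. For compound 2 (`Cc1cc(C(=O)NCCCCCCS)[nH]n1`) the read-out is > 50000 nM and this is a limit of the assay, not a number. Going by the values given here, the two results therefore provide no measured step.

Compound 3 (`CCC(=O)SCCCCCCNC(=O)c1cc(-c2ccncc2)n[nH]1`) keeps the rest of compound 1 and carries ethyl in place of benzyloxy on a carbonyl carbon. Cut one bond further out, the same difference reads benzyloxycarbonyl to propanoyl.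

Among the compounds with values here, with no measured step to draw on, the expected change in this assay is small, with a slight lean toward stronger growth inhibition and nothing expected beyond the usual scatter. The estimated move a 1.5-fold lower number from compound 1 to compound 3 (0.18 log units; within the scatter) is expected to remain modest. The estimate starts from compound 1 at 18200 nM alone, so its range is kept wide. For compound 3 the estimated value is 12000 nM with an expected range from 4000 nM to 36000 nM for this read-out.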

Compound 3, concentration for 50% growth inhibition: > 50000 nM
Compound 3 ended at the assay's limit (the forecaster's own chance of this, stated with the estimate: 10%); at least 4.1-fold (0.61 log units) between middle value and limit.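

In this assay, the position on a carbonyl carbon whose other neighbours are sulfur proves sensitive to the group it carries, and ethyl in place of benzyloxy gives an at least 2.7-fold higher number from compound 1 to compound 3 (0.43 log units; beyond the scatter). For compound 3, the read-out of > 50000 nM is a limit of the assay, not a number. The step therefore fixes a direction and a minimum size but no end point, and the full size stays unknown because compound 3 sits at this limit: the limit of > 50000 nM in this assay, at which 2 of the 3 values shown sit.

The change removes a six-membered aromatic ring of carbon only and an oxygen together, so this single pair cannot show which of the two, if either, matters for growth inhibition in this assay. Benzyl on the same carbonyl carbon would keep the ring without the oxygen and ethoxy would keep the oxygen without the ring, so how each would read against compound 1 remains the open question at this position.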